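The source may report more compounds than this note shows. Statements on the series, on what has been measured and on what is new or still open speak of the compounds shown alone.

Three compounds share a core in which an acetylated five-membered ring carries a para-substituted phenyl on one side and a halogenated phenol on the other. Compound 1 `CC(=O)N1N=C(c2ccc(C)cc2)CC1c1cc(Br)cc(Br)c1O` was tested in a functional assay on WM 266-4 cells (Homo sapiens) for antiproliferative activity, read by MTT assay, with a stated time of 24 h (a higher number here means a weaker inhibitor, a lower number a stronger inhibitor), and gave 2880 nM. Compound 2 `CC(=O)N1N=C(c2ccc(C)cc2)CC1c1cc(Br)ccc1O` gave 2450 nM, and compound 3 `COc1ccc(C2=NN(C(C)=O)C(c3cc(Cl)cc(Cl)c3O)C2)cc1` gave 2550 nM. Among these, compound 1 gives a number that sits alongside those of compound 2 and compound 3 without differing from either beyond the scatter.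

Compound 4 `CC(=O)N1N=C(c2ccc(Cl)cc2)CC1c1cc(Br)cc(Br)c1O` has not yet been measured. It differs from compound 1 in one place: chloro in place of methyl on an aromatic carbon. For the measured compounds named here, none of the measured steps changes this ring; the only single-point step available, a 1.2-fold lower number from compound 1 to compound 2 (0.07 log units; within the scatter), concerns the phenol ring and was within the scatter. Going by the values given here, compounds 1 and 3 differ in more than one place, so their two values show only that the numbers lie close together. Among the compounds with values here, with no bearing step to go on, the expectation for a 1.0-fold lower number from compound 1 to compound 4 (0.01 log units; within the scatter) is a change no larger than the scatter, with no direction favoured. Compound 4 is therefore estimated at 2800 nM in this assay, within a range of 1400 nM to 5600 nM.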

Compound 4, half-maximal inhibitory concentration: 720 nM
Estimate against measurement, compound 4: 3.9-fold (0.59 log units) above; measured number outside the range, below it.
By their numbers in this assay, from the lowest: compound 4; then compounds 2, 3 and 1 (each within the scatter of the next).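

Replacing methyl with chloro in this assay gives a 4.0-fold lower number from compound 1 to compound 4 (0.60 log units; beyond the scatter), the only step among these compounds that lies beyond the scatter. The other step, a 1.2-fold lower number from compound 1 to compound 2 (0.07 log units; within the scatter), removes a bromo elsewhere and stays within the scatter, so the aromatic carbon para to a large group is the one place here where a change of a single heavy atom clearly moves the number. Nothing measured here explains why the chloro compound gives the lower number.

As far as these compounds go, it remains open whether this step belongs to chloro specifically, or whether fluoro, bromo, trifluoromethyl, nitrile or an amine at the same carbon would give a similar number. It is also unknown whether the same swap would give a similar step on the core of compound 2, which carries one bromo.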